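Dropping bromo from compound 2: a limit result expected

A few compounds are considered here, and "the series" means these few. Any claim that something is new, unique, unknown or untested is made for them only; others in the source may bear on it.

Measured so far in a functional assay on SW480 cells (Homo sapiens) for cytotoxicity, read by MTT assay, with a stated time of 4 days; a lower number here means a stronger inhibitor, a higher number a weaker inhibitor:
Compound 1, `C=C1C[C@]23C[C@@]1(O)CC[C@H]2c1ccc(OS(=O)(=O)c2ccc(C)cc2)c(C)c1[C@@H]3Cn1cc(-c2ccc(C)cc2)nn1`, gives > 20000 nM, a limit of the assay.
Compound 2, `Cc1ccc(S(=O)(=O)Oc2ccc3c(c2C)[C@H](Cn2cc(-c4ccc(Br)cc4)nn2)[C@@]24CC(=O)[C@@](C)(CC[C@@H]32)C4)cc1`, gives > 20000 nM, likewise a limit.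
Compound 3, `Cc1ccc(-c2cn(C[C@H]3c4c(ccc(O)c4C)[C@@H]4CC[C@@]5(C)C[C@]43CC5=O)nn2)cc1`, gives > 20000 nM, again a limit.

Compound 2 thus stands where every value shown stands: the limit of > 20000 nM in this assay, at which 3 of the 3 values shown sit. Compound 4, `Cc1ccc(S(=O)(=O)Oc2ccc3c(c2C)[C@H](Cn2cc(-c4ccccc4)nn2)[C@@]24CC(=O)[C@@](C)(CC[C@@H]32)C4)cc1`, differs from compound 2 in one place: hydrogen in place of bromo on an aromatic carbon. Among the compounds with values here, all three measured values sit at this limit, and no measured pair differs in only one place, so the data hold no example of how far such a change moves this assay. The expected step from compound 2 to compound 4, a step that the limit leaves unreadable from compound 2 to compound 4, is none beyond the usual scatter. Compound 4 is estimated at 30000 nM, between 15000 nM and 80000 nM, most probably reported as a limit once more.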

Compound 4, half-maximal inhibitory concentration: > 20000 nM
Compound 4 was reported as a limit (the forecaster's own chance of this, stated with the estimate: 85%); the middle value lies beyond the limit too.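

No step can be read from compound 2 to compound 4, since both are reported only as a limit in this assay: the limit of > 20000 nM in this assay, at which 4 of the 4 values shown sit. The compounds shown leave open whether hydrogen in place of bromo changes cytotoxicity at all.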